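The source may hold more compounds than are shown below. What is called first, only, known or untested is meant among the compounds shown, and "the series" means these compounds.

Measured so far in a functional assay on the whole organism (strain Wister albino) for inhibition, with Rattus norvegicus as the target, read by paw edema, with stated times of 1 h and 3 h, at a dose of 50 mg/kg by the intraperitoneal route; a lower number here means less inhibition, a higher number more inhibition at the dose given (going by the name of the read-out):

- compound 1 `Cc1ccc([C@@H]2CN(C)[C@]3(C(=O)Nc4ccccc43)[C@]23Cc2ccccc2C3=O)cc1`: 27.4%
- compound 2 `CN1C[C@@H](c2ccccc2)[C@@]2(Cc3ccccc3C2=O)[C@@]12C(=O)Nc1ccccc12`: 42.5%
- compound 3 `CN1C[C@@H](c2cccs2)[C@@]2(Cc3ccccc3C2=O)[C@@]12C(=O)Nc1ccccc12`: 32.6%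

Compound 3 stands second highest of the three numbers in this assay. Its nearest neighbour is compound 1, separated by a number 5.2 percentage points higher from compound 1 to compound 3 (within the scatter), a gap within the scatter; the furthest is compound 2, separated by a number 9.9 percentage points lower from compound 2 to compound 3 (within the scatter), also within the scatter. Within the data shown here, the one step beyond the scatter in this set is a number 15.1 percentage points higher from compound 1 to compound 2 (beyond the scatter).

Compound 4 `COc1ccc([C@@H]2CN(C)[C@]3(C(=O)Nc4ccccc43)[C@]23Cc2ccccc2C3=O)cc1` is not yet measured. It differs from compound 3 as follows: 4-methoxyphenyl in place of thiophen-2-yl on a saturated ring carbon.

Both measured steps at the same saturated ring carbon bear on this change. The swap of 4-methylphenyl for thiophen-2-yl, a number 5.2 percentage points higher from compound 1 to compound 3 (within the scatter), and the swap of phenyl for thiophen-2-yl, a number 9.9 percentage points lower from compound 2 to compound 3 (within the scatter), each stayed within the scatter. The entering 4-methoxyphenyl resembles the 4-methylphenyl of compound 1 more than the phenyl of compound 2, and the six-membered aromatic rings so far gave numbers either side of compound 3. A step of about a number 0.6 percentage points lower from compound 3 to compound 4 (within the scatter) in this assay is therefore expected, that is none beyond the scatter.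

Compound 4 is estimated at 32% in this assay, with a range from 20% to 45%.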

Compound 4, a percentage reported as inhibition, in the whole organism at one dose (the size of the read-out at that dose, not a potency): 20.5%
Compound 4: the middle estimate sits 11.5 percentage points above what was measured; low and high end bracket the measured number.
By their numbers in this assay, from the lowest: compounds 4, 1, 3 and 2 (each within the scatter of the next, the first and the last beyond it).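

In this assay, the group on the saturated ring carbon now matters beyond the scatter for thiophen-2-yl against 4-methoxyphenyl, with a number 12.1 percentage points lower from compound 3 to compound 4 (beyond the scatter), whereas the earlier swaps involving thiophen-2-yl stayed within it. Methoxy in place of hydrogen on the aromatic carbon gives a number 22 percentage points lower from compound 2 to compound 4 (beyond the scatter), and with a number 15.1 percentage points higher from compound 1 to compound 2 (beyond the scatter) this places the phenyl of compound 2 beyond the scatter of both the 4-methylphenyl of compound 1 and the 4-methoxyphenyl of compound 4, although compound 3 with thiophen-2-yl stays within the scatter of compound 2. Methoxy in place of methyl gives a number 6.9 percentage points lower from compound 1 to compound 4 (within the scatter), so these two groups cannot be told apart at this aromatic carbon in these data.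

No measurement at hand accounts for the lower numbers with methoxy or methyl on this ring. The compounds shown leave open whether an amine or a carboxylic acid at this aromatic carbon would also fall below compound 2, and whether a longer chain in place of the methyl group on the ring nitrogen would shift the number in the phenyl series.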